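This account rests on a few compounds, and the source may have more. Where it says the series, first, only, none or still open, it means among the compounds named here.

Of the compounds shown here, three have so far been measured in an ADME assay on MT2 cells (Homo sapiens) for cytotoxicity, read by XTT assay, with a stated time of 4 days; a lower number here means that less compound is tolerated, a higher number that more compound is tolerated. Compound 1 `O=C(O)c1cc(-n2cccc2)ccc1O` gives 493000 nM in this assay. Compound 2 `c1cc(-c2nnn[nH]2)cc(-n2cccc2)c1` gives 436000 nM, which stands second highest of the three numbers and lies within the usual scatter of compound 1, so no order can be read between those two. Compound 3 `COC(=O)c1ccc(-c2noc(CSC#N)n2)cc1` gives 43700 nM, a number well below that of compound 2 and beyond the scatter.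

Compound 4 `O=C(O)c1cccc(-n2cccc2)c1` has not yet been measured. It differs from compound 2 in one place: carboxy in place of 1H-tetrazol-5-yl on an aromatic carbon. Among the compounds with values here, no pair of measured compounds shows this exact change, so there is no measured step to lean on. Compound 1, which also carries a carboxy and a 1H-pyrrol-1-yl group, gives 493000 nM, and compound 2 gives 436000 nM, the two being within the scatter of each other. On that basis the step of a 1.0-fold higher number from compound 2 to compound 4 (0.01 log units; within the scatter) is expected to be small, with no direction beyond the scatter. Compound 4 is therefore estimated at 450000 nM, with a likely range from 200000 nM to 900000 nM.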

Compound 4, half-maximal cytotoxic concentration: 302000 nM
Compound 4: the middle estimate sits 1.5-fold (0.17 log units) above what was measured, within the range that was stated.
By their numbers in this assay, from the lowest: compound 3; then compounds 4, 2 and 1 (each within the scatter of the next).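

In this assay, putting carboxy in place of 1H-tetrazol-5-yl on this aromatic carbon, meta to a 1H-pyrrol-1-yl group, gives a 1.4-fold lower number from compound 2 to compound 4 (0.16 log units; within the scatter), so this assay does not tell the two groups apart at this position. Hydrogen in place of hydroxy on an aromatic carbon gives a 1.6-fold lower number from compound 1 to compound 4 (0.21 log units; within the scatter), which also lies within the scatter, so that hydroxy leaves no readable mark on the tolerated concentration either. Nothing measured here offers an explanation for these two small steps.

As far as these compounds go, it remains open whether an amine or a primary amide on that same aromatic carbon would also stay within the scatter of compound 4. Also open, from the compounds shown here alone, is what a longer alkyl chain in place of the 1H-pyrrol-1-yl group would do.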